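This account rests on a few compounds, and the source may have more. Where it says the series, first, only, none or still open, it means among the compounds named here.

Measured so far in a functional assay on K562 cells (Homo sapiens) for cytotoxicity, read by thymidine incorporation, with a stated time of 48 h, tested at 1.25 ug/mL; on this read-out lower numbers stand for less inhibition and higher numbers for more inhibition at the one concentration tested (going by the name of the read-out):
compound 1 `O=c1nc2c(cn1Cc1ccccc1)ncn2Cc1ccccc1` gives 5.7%
compound 2 `O=C1Nc2c(ncn2Cc2ccccc2)C(C#CC2CC2)N1Cc1ccccc1` gives 42%
compound 3 `O=C1Nc2c(ncn2Cc2ccccc2)C(c2ccccc2)N1Cc1ccccc1` gives 85%

Compound 3 stands highest of the three in this assay; its nearest neighbour is compound 2, separated by a number 43 percentage points higher from compound 2 to compound 3 (beyond the scatter), and compound 1 lies furthest below it.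

Compound 4 `CC1c2ncn(Cc3ccccc3)c2NC(=O)N1Cc1ccccc1` differs from compound 3 by methyl in place of phenyl on a saturated ring carbon. Within the data shown here, the only measured step at this saturated ring carbon is a number 43 percentage points higher from compound 2 to compound 3 (beyond the scatter), a large rise when phenyl entered; no step yet shows methyl at this position. Taking the phenyl out again is therefore expected to cost a good part of that gain, a downward step of about a number 50 percentage points lower from compound 3 to compound 4 (beyond the scatter) in this assay. For compound 4 the estimate in this assay is 35%, with a range from 10% to 65%.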

Compound 4, a percentage reported as inhibition, at one concentration (the size of the read-out at that concentration, not a potency): 33%
Beside the measured number, compound 4's estimate is 2 percentage points above it; the range from low to high includes it.
By their numbers in this assay, from the lowest: compound 1; then compounds 4 and 2 (each within the scatter of the next); then compound 3.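

In this assay phenyl at this saturated ring carbon now stands apart from both other groups, as removing it for methyl gives a large fall (a number 52 percentage points lower from compound 3 to compound 4 (beyond the scatter)). Methyl and 2-cyclopropylethynyl cannot be separated here (a number 9 percentage points lower from compound 2 to compound 4 (within the scatter)), so the smaller methyl and the longer alkyne-bearing group offer no trend with group size across these compounds. Nothing measured on these compounds explains why phenyl stands apart.

From the compounds shown here alone, whether the high level belongs to phenyl alone remains open. A pyridine ring, a cyclohexyl ring or an amine at this saturated ring carbon could settle that.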